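This account rests on a few compounds, and the source may have more. Where it says the series, first, only, none or still open, it means among the compounds named here.

Measured in an assay on CHO cells for displacement of a labelled ligand from adenosine receptor A3 (Homo sapiens), read by scintillation counting, with a stated time of 120 min, tested at 1 uM; a higher number here means more inhibition at the concentration tested (going by the name of the read-out), a lower number less inhibition:
compound 1 `N#Cc1c(N)nc(SCC(N)=O)c(C#N)c1-c1ccc(OCC2CC2)cc1` gives 8%
compound 2 `N#Cc1c(N)nc(SCc2ccn[nH]2)c(C#N)c1-c1ccc(OCC2CC2)cc1` gives 6%
compound 3 `N#Cc1c(N)nc(SCc2ncn[nH]2)c(C#N)c1-c1ccc(OCC2CC2)cc1` gives 1%

Compound 3 has the lowest of the three numbers in this assay, but the steps to it from compound 2 a number 5 percentage points lower from compound 2 to compound 3 (within the scatter) and from compound 1 a number 7 percentage points lower from compound 1 to compound 3 (within the scatter) are both within the scatter, so the three compounds cannot be ranked against one another.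

Compound 4 `CNC(=O)CSc1nc(N)c(C#N)c(-c2ccc(OCC3CC3)cc2)c1C#N` differs from compound 3 in one place: methylcarbamoyl in place of 1H-1,2,4-triazol-5-yl on a saturated chain carbon bound to a sulfur. The measured steps that bear on this change are those exchanging the carbamoyl for azoles, a number 2 percentage points lower from compound 1 to compound 2 (within the scatter) and a number 7 percentage points lower from compound 1 to compound 3 (within the scatter), neither of which left the scatter. Compound 4 reverses that kind of exchange with an added methyl on the amide nitrogen, so the author expects no step beyond the scatter, a number 5 percentage points higher from compound 3 to compound 4 (within the scatter). For compound 4 the estimate in this assay is 6%, within 0% to 16%.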

Compound 4, a percentage reported as inhibition, at one concentration (the size of the read-out at that concentration, not a potency): 3%
Compound 4: the middle estimate sits 3 percentage points above what was measured; the range from low to high includes it.
By their numbers in this assay, from the lowest: compounds 3, 4, 2 and 1 (each within the scatter of the next).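

In this assay, a methyl in place of the hydrogen on the amide nitrogen gives a number 5 percentage points lower from compound 1 to compound 4 (within the scatter) and so adds a change on the amide itself, one that does not leave the scatter. Methylcarbamoyl on the saturated chain carbon bound to a sulfur also stays within the scatter of both azoles, with a number 2 percentage points higher from compound 3 to compound 4 (within the scatter) and a number 3 percentage points lower from compound 2 to compound 4 (within the scatter). No measurement offers an explanation for these results. Going by these compounds, what remains open is whether an amine, a carboxylic acid or a longer chain at this place would give a step beyond the scatter.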